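Amide aryl variation in a thioacetamide series: working notes

This account rests on a few compounds, and the source may have more. Where it says the series, first, only, none or still open, it means among the compounds named here.

Measured so far:
- compound 1, `COc1cccc(NC(=O)CSc2nc(Nc3ccccc3)c3ccccc3n2)c1`: 10000 nM
- compound 2, `O=C(CSc1nc(Nc2ccccc2)c2ccccc2n1)Nc1ccc(C(F)(F)F)cc1`: 8670 nM

Compound 1 gives the highest of the two numbers in a functional assay on MGC-803 cells (Homo sapiens) for inhibition, read by MTT assay, with a stated time of 72 h (a lower number here means a stronger inhibitor, a higher number a weaker inhibitor), and compound 2 sits nearest: a 1.2-fold lower number from compound 1 to compound 2 (0.06 log units; within the scatter). The two values of compound 1 and compound 2 therefore cannot be ordered.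

The unmeasured compound 3, `CCc1ccc(NC(=O)CSc2nc(Nc3ccccc3)c3ccccc3n2)cc1`, differs from compound 1 only on the amide-type nitrogen: 4-ethylphenyl in place of 3-methoxyphenyl on an amide-type nitrogen.

Among the compounds with values here, the one measured step that bears on this position is the exchange of the aryl group on the same amide-type nitrogen, a 1.2-fold lower number from compound 1 to compound 2 (0.06 log units; within the scatter), which stayed within the scatter. Within the data shown here, no other step touches this position. On that basis no step beyond the scatter is expected from compound 1 to compound 3 in this assay, in either direction: a 1.1-fold lower number from compound 1 to compound 3 (0.05 log units; within the scatter). Compound 3 is thus estimated at 9000 nM, with a range from 3000 nM to 30000 nM.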

Compound 3, half-maximal inhibitory concentration: > 50000 nM
Compound 3 gave a limit, no number; the forecaster's own chance of this, stated with the estimate: 30%; middle value at least 5.5-fold (0.74 log units) away from the limit.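

Compound 3 gives a limit and not a number: the limit of > 50000 nM in this assay, at which 1 of the 3 values shown sits.

Even so, this position proves sensitive to the choice of aryl group in this assay, which the earlier step, a 1.2-fold lower number from compound 1 to compound 2 (0.06 log units; within the scatter), did not show. The change to 4-ethylphenyl on the amide-type nitrogen gives an at least 5.0-fold higher number from compound 1 to compound 3 (0.69 log units; beyond the scatter), and ethyl in place of trifluoromethyl on an aromatic carbon gives an at least 5.7-fold higher number from compound 2 to compound 3 (0.76 log units; beyond the scatter). Compound 3 is therefore the weakest of the three, though the limit leaves the true size of both steps unknown.

As far as these compounds go, what a 4-methylphenyl group, a longer chain such as 4-propylphenyl, or an amine on the same aryl ring would give remains open. These values also cannot say whether the ethyl group alone accounts for the step.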